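Triazole aryl exchange on a trifluoromethyl chromene scaffold

The source may hold more compounds than are shown below. What is called first, only, known or untested is meant among the compounds shown, and "the series" means these compounds.

Compound 1 `O=C(O)C1=Cc2ccccc2OC1(OCc1cc(-c2ccc([N+](=O)[O-])cc2)no1)C(F)(F)F`: 100000 nM
Compound 2 `CCOC(=O)C1=Cc2ccccc2OC1(OCc1cn(-c2ccc(F)c([N+](=O)[O-])c2)nn1)C(F)(F)F`: 13200 nM
Compound 3 `CCOC(=O)C1=Cc2ccccc2OC1(OCc1cc(-c2ccc(C)cc2)no1)C(F)(F)F`: > 150000 nM

In a functional assay on DU-145 cells (Homo sapiens) for inhibition, read by MTT assay, with a stated time of 24 h (on this read-out lower numbers stand for stronger inhibition and higher numbers for weaker inhibition), compound 2 gives 13200 nM, the lowest of the two numbers recorded here; compound 1 gives 100000 nM, a gap beyond the usual scatter. For compound 3 this assay reports only a limit, > 150000 nM, which is the limit of > 150000 nM in this assay, at which 1 of the 3 values shown sits. Compound 4 `CCOC(=O)C1=Cc2ccccc2OC1(OCc1cn(-c2cccc(OC)c2)nn1)C(F)(F)F` differs from compound 2 in one place: 3-methoxyphenyl in place of 4-fluoro-3-nitrophenyl on an aromatic nitrogen. Among the compounds with values here, no measured pair carries this change, so its size is not known from the data; a modest weakening, or no change beyond the scatter, is expected. Compound 4 is therefore estimated to give 30000 nM in this assay, within 8000 nM to 120000 nM, an expected step of a 2.3-fold higher number from compound 2 to compound 4 (0.36 log units; beyond the scatter).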

Compound 4, half-maximal inhibitory concentration: > 150000 nM
Compound 4 gave a limit, no number; the forecaster's own chance of this, stated with the estimate: 25%; middle value at least 5.0-fold (0.69 log units) away from the limit.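

With 3-methoxyphenyl in place of 4-fluoro-3-nitrophenyl on the aromatic nitrogen, the aryl group at this position proves to matter in this assay, with an at least 11-fold higher number from compound 2 to compound 4 (1.05 log units; beyond the scatter). Compound 4 gives a limit rather than a number, so the full size of this step cannot be read: the limit of > 150000 nM in this assay, at which 2 of the 4 values shown sit.

The compounds shown do not separate the contribution of the nitro group from that of the fluorine in compound 2. They also leave open whether an amine or a nitrile on this aryl ring would keep the activity of compound 2.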